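Nitro added to the carboxyphenyl of compound 2

The source may report more compounds than this note shows. Statements on the series, on what has been measured and on what is new or still open speak of the compounds shown alone.

Measured so far in an assay on isolated protein for activation of cGMP-dependent protein kinase 1 (Homo sapiens), read by ADP-Glo, with stated times of 30 min and 2 h; a higher number here means that more compound is needed for the effect, a lower number that less compound is needed:
compound 1, `OC[C@@H](O[C@H]1CCCN(Cc2ncc[nH]2)[C@H]1c1ccccc1)c1cc(Cl)cc(Cl)c1`: > 200000 nM
compound 2, `O=C(O)c1ccc(CN2CCC[C@H](O[C@H](CO)c3cc(Cl)cc(Cl)c3)[C@@H]2c2ccccc2)cc1`: 77000 nM

Compound 2 holds the only number shown; in this assay compound 2 gives 77000 nM. For compound 1 the value in this assay is a limit of the assay, not a number. Going by the values given here, the one measured step, an at least 2.5-fold lower number from compound 1 to compound 2 (0.41 log units; beyond the scatter), rests on the limit of > 200000 nM in this assay, at which 1 of the 2 values shown sits, and so only sets a floor on its size.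

Compound 3, `O=C(O)c1ccc(CN2CCC[C@H](O[C@H](CO)c3cc(Cl)cc(Cl)c3)[C@@H]2c2ccccc2)c([N+](=O)[O-])c1`, differs from compound 2 by nitro in place of hydrogen on an aromatic carbon. Among the compounds with values here, no measured step touches this part of the shared core: the single measured step concerns the group on the saturated chain carbon bound to the ring amine nitrogen, not a substituent on the carboxyphenyl itself. Nothing in the two values therefore points in either direction, and the expectation for this assay is a step not beyond the scatter.

Compound 3 is estimated at 60000 nM, expected between 20000 nM and 200000 nM. That estimate means a 1.3-fold lower number from compound 2 to compound 3 (0.11 log units; within the scatter), expected to stay within the usual scatter.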

Compound 3, half-maximal effective concentration in the cGMP-dependent protein kinase 1 assay: 13000 nM
Compound 3: middle estimate off by 4.6-fold (0.66 log units), on the high side, and the stated range ends above it.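

Nitro on the aromatic carbon ortho to a large group and meta to a carboxy group gives in the cGMP-dependent protein kinase 1 assay a 5.9-fold lower number from compound 2 to compound 3 (0.77 log units; beyond the scatter) and is the first sign that the carboxyphenyl ring itself moves the number, not only the group on the saturated chain carbon. In a physicochemical assay for solubility, at pH 7 (on this read-out higher numbers stand for higher solubility and lower numbers for lower solubility), compound 2 gives 85000 nM and compound 3 gives 110000 nM; the same change reads a 1.3-fold higher number from compound 2 to compound 3 (0.11 log units; within the scatter) and so does not separate the two compounds on that read-out. In the cGMP-dependent protein kinase 1 assay the longer step of an at least 15-fold lower number from compound 1 to compound 3 (1.18 log units; beyond the scatter) gives only a floor on its size, as compound 1 gives > 200000 nM, which is a limit of the assay and not a number: the limit of > 200000 nM in the cGMP-dependent protein kinase 1 assay, at which 1 of the 3 values shown sits.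

The compounds shown hold only hydrogen and nitro at this place, so it stays open whether an amine, a methoxy group or fluorine would lower the number as well. Also open, as far as these compounds go, is whether nitro gives a similar step on other carbons of this ring.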